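Replacing an Ethoxyphenyl Group with a Dimethylphenyl Group

The source may hold more compounds than are shown below. What is called first, only, known or untested is meant among the compounds shown, and "the series" means these compounds.

Measured compounds:
compound 1 `CC1(c2ccc(F)cc2)NC(=O)N(CC(O)CN2CCN(c3ccccc3)CC2)C1=O` gives 223 nM
compound 2 `CC1(c2ccc(F)cc2)NC(=O)N(CC(O)CN2CCN(c3ccccc3F)CC2)C1=O` gives 234 nM
compound 3 `CCOc1ccccc1N1CCN(CC(O)CN2C(=O)NC(C)(c3ccc(F)cc3)C2=O)CC1` gives 10 nM

In an assay on HEK293 cells for displacement of a labelled ligand from 5-hydroxytryptamine receptor 7 (Homo sapiens) (on this read-out lower numbers stand for stronger inhibition and higher numbers for weaker inhibition), compound 3 stands lowest of the three, with compound 1 the nearest and compound 2 the furthest. Compound 4 `Cc1ccc(N2CCN(CC(O)CN3C(=O)NC(C)(c4ccc(F)cc4)C3=O)CC2)cc1C` differs from compound 3 by 3,4-dimethylphenyl in place of 2-ethoxyphenyl on an amine nitrogen in a ring. Within the data shown here, two measured steps bear on this: a 22-fold lower number from compound 1 to compound 3 (1.35 log units; beyond the scatter) and a 23-fold lower number from compound 2 to compound 3 (1.37 log units; beyond the scatter), both large, while a 1.0-fold higher number from compound 1 to compound 2 (0.02 log units; within the scatter). Among the measured compounds shown here, removing the ethoxy group should therefore cost most of that gain; no measured step tells what the 3,4-dimethylphenyl group adds. Compound 4 is expected to show a 15-fold higher number from compound 3 to compound 4 (1.18 log units; beyond the scatter), a weaker result. The estimate for compound 4 is 150 nM, with a range from 40 nM to 600 nM.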

Compound 4, inhibition constant: 177 nM
Compound 4: middle estimate off by 1.2-fold (0.07 log units), on the low side, within the range that was stated.
By their numbers in this assay, from the lowest: compound 3; then compounds 4, 1 and 2 (each within the scatter of the next).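

In this assay the change to 3,4-dimethylphenyl gives an 18-fold higher number from compound 3 to compound 4 (1.25 log units; beyond the scatter), so a carbon-only substituted ring does not keep what 2-ethoxyphenyl gave on this amine nitrogen. It also leaves the number level with the plain phenyl (a 1.3-fold lower number from compound 1 to compound 4 (0.10 log units; within the scatter)) and with 2-fluorophenyl (a 1.3-fold lower number from compound 2 to compound 4 (0.12 log units; within the scatter)), so among these four compounds only 2-ethoxyphenyl stands apart. Nothing measured here explains why. The compounds shown leave open whether the ring oxygen or the ethyl chain of the ethoxy group carries the gain, and 2-methoxyphenyl or 2-propylphenyl groups would help separate the two.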